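This account rests on a few compounds, and the source may have more. Where it says the series, first, only, none or still open, it means among the compounds named here.

Measured in a functional assay on RAW264.7 cells (Mus musculus) for inhibition, read by Griess assay, with stated times of 2 h and 18 h; a lower number here means a stronger inhibitor, a higher number a weaker inhibitor:
Compound 1 `CC(=O)O[C@@H]1CC[C@]2(C)C(CCc3ccoc3)=C(C)C(=O)[C@@H](O)[C@H]2C1(C)C`: 22500 nM
Compound 2 `CC(=O)O[C@@H]1CC[C@@]2(C)[C@@H](C(=O)[C@H](O)[C@@H](C)[C@]2(O)CCc2ccoc2)C1(C)C`: > 50000 nM

Compound 2 gives only a limit of the assay, not a number: > 50000 nM.

Compound 3 `C[C@@H]1[C@@H](O)C(=O)[C@H]2C(C)(C)CCC[C@]2(C)[C@@]1(O)CCc1ccoc1` has not yet been measured. It has hydrogen in place of acetoxy on a saturated ring carbon, next to the ring atom that bears two methyl groups: hydrogen in place of acetoxy on a saturated ring carbon. Among the compounds with values here, no measured pair shows this change alone, so the expectation is cautious. The expected step, an at least 1.1-fold lower number from compound 2 to compound 3 (0.04 log units; that floor lies within the scatter), lies within the scatter, with no clear direction in this assay. The estimate for compound 3 is 45000 nM, with an expected range of 15000 nM to 100000 nM.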

Compound 3, half-maximal inhibitory concentration: > 50000 nM
Compound 3 ended at the assay's limit (the forecaster's own chance of this, stated with the estimate: 55%); middle value at least 1.1-fold (0.04 log units) away from the limit.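

Compound 2 and compound 3 both stand at a limit of this assay, not at a number, and no step can be read between them. The compounds shown leave open whether hydrogen in place of acetoxy changes inhibition at all.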